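Indole-bearing pyran series: moving fluorine on the phenyl ring

The source may report more compounds than this note shows. Statements on the series, on what has been measured and on what is new or still open speak of the compounds shown alone.

Measured so far:
- compound 1 `N#CC1=C(N)OC(c2c[nH]c3ccccc23)=C(C#N)C1c1ccccc1F`: "not active" (no number reported)
- compound 2 `COc1ccc(C2C(C#N)=C(N)OC(c3c[nH]c4ccccc34)=C2C#N)cc1OC`: 28.1%

Compound 1 carries a 2-fluorophenyl group on the shared core. In a functional assay, tested at 400 ug/mL (on this read-out lower numbers stand for a weaker effect and higher numbers for a stronger effect at the one concentration tested), compound 1 is reported as "not active" (no number reported), so no single number stands for it, and it cannot be placed on a scale against compound 2. Compound 2, which carries a 3,4-dimethoxyphenyl group in the same place, gives 28.1% in this assay. Within the data shown here, no pair of measured compounds differs in one place, so no step has been worked out.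

Compound 3 `N#CC1=C(N)OC(c2c[nH]c3ccccc23)=C(C#N)C1c1ccc(F)cc1` is not yet measured. It differs from compound 1 by 4-fluorophenyl in place of 2-fluorophenyl on a saturated ring carbon. Both compounds keep the 1H-indol-3-yl group, the amino group and the two cyano groups on the shared core. With compound 1 showing no effect and only compound 2 giving a number, any step from compound 1 to compound 3 in this assay is expected to be small, at most a modest gain toward a weak effect, and may well stay within the scatter. On that basis compound 3 is estimated at 15% in this assay, in the range 0% to 35%.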

Compound 3, a percentage reported as activity, at one concentration (the size of the read-out at that concentration, not a potency): 26.7%
Compound 3: middle estimate off by 11.7 percentage points, on the low side, and the stated range covers the measured number.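

At the saturated ring carbon, the two fluorophenyl isomers part clearly in this assay: compound 1, with 2-fluorophenyl, gives "not active" (no number reported), whereas compound 3, with 4-fluorophenyl, gives 26.7% on the otherwise identical shared core, although the size of this change cannot be read without a number for compound 1. The group at this carbon can also differ considerably without a readable difference, with a number 1.4 percentage points lower from compound 2 to compound 3 (within the scatter) on exchanging 3,4-dimethoxyphenyl for 4-fluorophenyl, so these two groups stand level in this assay at the one concentration tested. No measured evidence is available to explain either observation.

The compounds shown leave open whether 3-fluorophenyl or unsubstituted phenyl at this carbon would resemble compound 1 or compound 3, and whether 2-chlorophenyl or 2-methoxyphenyl would also give no reported number. Also open, from the compounds shown here alone, is how this assay would respond to a phenyl ring carrying a carboxylic acid or an aminomethyl group in this place, since only fluorine and methoxy substituents appear here.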